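This account rests on a few compounds, and the source may have more. Where it says the series, first, only, none or still open, it means among the compounds named here.

Compound 1 `COc1cccc(/C=C2\SC(=O)N(Cc3ccc(C(=O)O)cc3)C2=O)c1` carries a shared core decorated with a 3-methoxyphenyl group, and in a functional assay on HT-29 cells (Homo sapiens) for cytotoxicity, read by MTT assay, with a stated time of 24 h (a higher number here means a weaker inhibitor, a lower number a stronger inhibitor), compound 1 gives 48000 nM. Among the three measured compounds this is the second highest number. Compound 2 `COc1ccc(/C=C2\SC(=O)N(Cc3ccc(C(=O)O)cc3)C2=O)cc1` gives 44000 nM in this assay, and compound 3 `O=C(O)c1ccc(CN2C(=O)S/C(=C\c3cccs3)C2=O)cc1` gives 88000 nM. The three numbers sit close together: a 1.1-fold lower number from compound 1 to compound 2 (0.04 log units; within the scatter), a 1.8-fold higher number from compound 1 to compound 3 (0.26 log units; within the scatter), and a 2.0-fold higher number from compound 2 to compound 3 (0.30 log units; within the scatter).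

The untested compound 4 `Cc1ccc(/C=C2\SC(=O)N(Cc3ccc(C(=O)O)cc3)C2=O)cc1` differs from compound 1 in one place: 4-methylphenyl in place of 3-methoxyphenyl on a double-bonded chain carbon bound to a double-bonded ring carbon.

Going by the values given here, no measured step makes exactly this exchange, so the expectation rests on the steps that vary the same aryl group on the same chain carbon. The step from compound 1 to compound 2 alters the same group and stays within the scatter, as does the step from compound 1 to compound 3, where even a different ring kind enters. Among the compounds with values here, both steps suggest that the core tolerates variation at this site without a shift beyond the scatter in this assay, though only three compounds support that view.

Compound 4 is therefore expected to give 50000 nM, within a range of 20000 nM to 125000 nM, which means an estimated step of a 1.0-fold higher number from compound 1 to compound 4 (0.02 log units; within the scatter).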

Compound 4, half-maximal inhibitory concentration: 72000 nM
Estimate against measurement, compound 4: 1.4-fold (0.16 log units) below; low and high end bracket the measured number.
By their numbers in this assay, from the lowest: compounds 2, 1, 4 and 3 (each within the scatter of the next).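

The 4-methylphenyl group carries no oxygen, yet compound 4 stays within the scatter of all three earlier compounds in this assay (a 1.5-fold higher number from compound 1 to compound 4 (0.18 log units; within the scatter); a 1.2-fold lower number from compound 3 to compound 4 (0.09 log units; within the scatter); a 1.6-fold higher number from compound 2 to compound 4 (0.21 log units; within the scatter)). Going by these compounds alone, the last of these steps is the first to exchange methyl for methoxy on an aromatic carbon with nothing else altered, so an oxygen in this group is not required for a number in this range. No measurement bears on why the four numbers lie so close together.

The compounds shown leave open whether any group on this double-bonded chain carbon can move the number beyond the scatter, since all four carry a single small aromatic ring there, with only a methoxy or a methyl as a substituent, or none. Going by these compounds, an amine or a hydroxyl on the phenyl ring, a second ring joined to it, or a longer chain in place of the methyl might answer that, and the carboxylic acid of the shared core stays untested as a point of variation.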